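This account rests on a few compounds, and the source may have more. Where it says the series, first, only, none or still open, it means among the compounds named here.

Working notes on the series. The shared core of compound 3 `Cc1cc(-c2c(C)nn(-c3nc(-c4ccc(Cl)c(Cl)c4)c(SC(C)C)s3)c2C(=O)O)cc(C)n1` carries, on an aromatic carbon of the five-membered ring, a group that is varied across the set. Within the data shown here, in a functional assay on BJAB cells (Homo sapiens) for antiproliferative activity, with a stated time of 4 days (on this read-out higher numbers stand for an effect only at larger amounts of compound and lower numbers for an effect already at smaller amounts), compound 3 gives 580 nM, the lowest of the three numbers so far. Compound 1 `Cc1nn(-c2nc(-c3ccc(Cl)c(Cl)c3)c(SC(C)C)s2)c(C(=O)O)c1-c1cccc(Cl)c1C` gives 5100 nM, and compound 2 `Cc1nn(-c2nc(-c3ccc(Cl)c(Cl)c3)c(SC(C)C)s2)c(C(=O)O)c1-c1cnccn1` gives 14000 nM; both steps to compound 3 lie beyond the scatter, an 8.8-fold lower number from compound 1 to compound 3 (0.94 log units; beyond the scatter) and a 24-fold lower number from compound 2 to compound 3 (1.38 log units; beyond the scatter).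

Compound 4 `Cc1nn(-c2nc(-c3ccc(Cl)c(Cl)c3)c(SC(C)C)s2)c(C(=O)O)c1-c1ccccc1C(F)(F)F` differs from compound 3 in one place: 2-(trifluoromethyl)phenyl in place of 2,6-dimethylpyridin-4-yl on an aromatic carbon. The change most closely related is that of compound 1, where a six-membered aromatic ring of carbon only stands in the same place and gives a number well above compound 3, shown by an 8.8-fold lower number from compound 1 to compound 3 (0.94 log units; beyond the scatter) read in reverse. Compound 2, with a ring of two nitrogens, gives the highest number. Compound 4 again carries a ring of carbon only, so in this assay a higher number than compound 3 is expected, of a size near a 5.2-fold higher number from compound 3 to compound 4 (0.71 log units; beyond the scatter). Compound 4 is thus estimated at 3000 nM, within 800 nM to 12000 nM.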

Compound 4, half-maximal effective concentration: 5200 nM
Compound 4: the middle estimate sits 1.7-fold (0.24 log units) below what was measured; the range from low to high includes it.
By their numbers in this assay, from the lowest: compound 3; then compounds 1 and 4 (each within the scatter of the next); then compound 2.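

In this assay, 2-(trifluoromethyl)phenyl and 3-chloro-2-methylphenyl cannot be told apart at this aromatic carbon (a 1.0-fold higher number from compound 1 to compound 4 (0.01 log units; within the scatter)), so two differently substituted carbon-only rings now give the same reading. Compound 3 stands apart from this second carbon-only ring as well (a 9.0-fold higher number from compound 3 to compound 4 (0.95 log units; beyond the scatter)), so its lower number no longer rests on the comparison with compound 1 alone. A ring nitrogen by itself does not account for this, as compound 2 goes against such a pattern and its pyrazin-2-yl group still reads higher than 2-(trifluoromethyl)phenyl (a 2.7-fold lower number from compound 2 to compound 4 (0.43 log units; beyond the scatter)); no measurement at hand bears on the reason for these differences.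

The compounds shown do not separate the contribution of the pyridine nitrogen from that of the two methyl groups of 2,6-dimethylpyridin-4-yl. Also open, going by these compounds, is how the number responds to an amine or a longer alkyl chain on that ring.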